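Series notes: swapping the substituent on the five-membered core

The compounds below may be only part of what the source reports. "The series", "measured", "known", "first", "only" and "open" are said of these compounds alone.

Measured so far:
compound 1, `Cc1c(C=O)cc(-c2ccc(S(C)(=O)=O)cc2)n1-c1ccc(F)c(F)c1`, 52%
compound 2, `Cc1c(/C=N\O)cc(-c2ccc(S(C)(=O)=O)cc2)n1-c1ccc(F)c(F)c1`, 27%

In a functional assay on the whole organism (strain Swiss albino) for inhibition, with Mus musculus as the target, in the writhing test, with a stated time of 30 min, at a dose of 20 mg/kg by the oral route (on this read-out higher numbers stand for a stronger effect at the one dose given and lower numbers for a weaker effect), compound 2 gives 27%, the lowest of the two numbers; the nearest is compound 1 with 52%. Within the data shown here, the only measured step is a number 25 percentage points lower from compound 1 to compound 2 (beyond the scatter), so exchange of a two-heavy-atom group for a three-heavy-atom group on this aromatic carbon cost a modest amount.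

Compound 3, `Cc1c(C#N)cc(-c2ccc(S(C)(=O)=O)cc2)n1-c1ccc(F)c(F)c1`, reverses that direction: a group of 2 heavy atoms (1 carbon, 1 nitrogen; no ring) in place of a group of 3 heavy atoms (1 carbon, 1 nitrogen, 1 oxygen; no ring), on an aromatic carbon. The change is not the exact reverse of the measured step, since a cyano group enters rather than the group of compound 1, but it again moves from three heavy atoms to two. An upward step is therefore expected in this assay, of roughly the size seen between compound 1 and compound 2, though with wide uncertainty.

Compound 3 is estimated at 45%, with a range from 25% to 65%. That estimate corresponds to an expected a number 18 percentage points higher from compound 2 to compound 3 (beyond the scatter).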

Compound 3, a percentage reported as inhibition, in the whole organism at one dose (the size of the read-out at that dose, not a potency): 38%
Compound 3: the middle estimate sits 7 percentage points above what was measured; low and high end bracket the measured number.
By their numbers in this assay, from the lowest: compound 2; then compound 3; then compound 1.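

In this assay the position on the aromatic carbon separates all three groups: cyano brings a number 11 percentage points higher from compound 2 to compound 3 (beyond the scatter) but still gives a number 14 percentage points lower from compound 1 to compound 3 (beyond the scatter). Heavy-atom count alone therefore does not set the read-out at this position, since formyl and cyano each have 2 heavy atoms, and yet their compounds differ beyond the scatter. Going from the three-atom group to a two-atom group raises the number in both measured cases, but the size of the gain depends on which two-atom group enters, and no measurement is available to account for this order.

Going by these compounds, whether a carboxylic acid or an amine on this aromatic carbon would read above compound 1 remains open. Also open, on these data alone, is whether the order of the three compounds holds at other doses.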